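Swapping 2,4-difluorophenyl for 1-benzofuran-2-yl

The compounds below may be only part of what the source reports. "The series", "measured", "known", "first", "only" and "open" are said of these compounds alone.

Going by the values given here, in an ADME assay on MRC5 cells (Homo sapiens) for inhibition, with a stated time of 72 h (a lower number here means that less compound is needed, a higher number that more compound is needed for the effect), compound 3 `CO[C@H]1CC[C@H](NC(=O)c2n[nH]cc2NC(=O)c2ccc(F)cc2F)CC1` gives 11000 nM, the only true number so far. Compound 1 `COc1cccc(OC)c1C(=O)Nc1c[nH]nc1C(=O)NCC1CCCCC1` gives > 50000 nM, which is a limit of the assay and not a number. Compound 2 `CCCCCNC(=O)c1n[nH]cc1NC(=O)c1c(OC)cccc1OC` gives > 50000 nM, also a limit. Compound 4 `CO[C@H]1CC[C@H](NC(=O)c2n[nH]cc2NC(=O)c2cc3ccccc3o2)CC1` differs from compound 3 in one place: 1-benzofuran-2-yl in place of 2,4-difluorophenyl on a carbonyl carbon. Among the compounds with values here, the only measured step, a step that the two limits leave unreadable from compound 1 to compound 2, has no readable size and concerns a saturated chain, not the group on the carbonyl carbon. Within the data shown here, no measured step therefore points in any direction, and none is expected beyond the scatter in this assay. The expected change is a 1.1-fold higher number from compound 3 to compound 4 (0.04 log units; within the scatter). For compound 4 the estimate is 12000 nM, with an expected range of 3000 nM to 50000 nM.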

Compound 4, half-maximal effective concentration: 800 nM
Estimate against measurement, compound 4: 15-fold (1.18 log units) above, and the stated range ends above it.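

In this assay, changing only the group on the carbonyl carbon, 1-benzofuran-2-yl in place of 2,4-difluorophenyl, gives a 14-fold lower number from compound 3 to compound 4 (1.14 log units; beyond the scatter). This shows that a change at this position alone can move the number beyond the scatter. The earlier compounds could not show this, as the one step among them cannot be read and both of its compounds sit at a limit: the limit of > 50000 nM in this assay, at which 2 of the 4 values shown sit.

This single pair cannot separate the part played by the added oxygen from that of the lost fluorines. On these data alone, how a plain phenyl or a furan-2-yl would read at this place stays open.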